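Cassette rat clearance across two cores, fluoro to methoxy

A few compounds are considered here, and "the series" means these few. Any claim that something is new, unique, unknown or untested is made for them only; others in the source may bear on it.

Measured compounds:
compound 1 `O=C(C[C@]1(O)CC[C@@H](Cc2ccc(F)cc2)CC1)Nc1ccc2[nH]c(=O)oc2c1` — 36.8 mL/min/kg
compound 2 `COc1ccc(C[C@H]2CC[C@](O)(CC(=O)Nc3ccc4[nH]c(=O)oc4c3)CC2)cc1` — 45.9 mL/min/kg
compound 3 `O[C@]1(Cc2cc(-c3cn[nH]c3)on2)CC[C@H](Cc2ccc(F)cc2)CC1` — 30 mL/min/kg

All three were run in an ADME assay on the whole organism (strain Sprague-Dawley) for pharmacokinetics, with Rattus norvegicus as the target, using cassette dosing; a lower number here means slower removal, a higher number faster removal of the compound. Compound 1 and compound 2 share one core and differ only by methoxy in place of fluoro on an aromatic carbon; in this assay the step is a 1.2-fold higher number from compound 1 to compound 2 (0.10 log units; within the scatter). Compound 3 carries a different core, and the difference between the two cores is not broken down here. The value of compound 3 sits close to that of compound 1 and also close to that of compound 2, all within the usual scatter of this assay, so no ordering among the three is claimed.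

Compound 4 `COc1ccc(C[C@H]2CC[C@](O)(Cc3cc(-c4cn[nH]c4)on3)CC2)cc1` is not yet measured. It differs from compound 3 by methoxy in place of fluoro on an aromatic carbon, the same change as that from compound 1 to compound 2, and at the same place on the ring. Among the compounds with values here, only one measured pair shows this change, so the expectation for compound 4 rests on that single step together with the value of compound 3. The change is expected to be about as small in the new core as in the old one: an estimated step of a 1.2-fold higher number from compound 3 to compound 4 (0.08 log units; within the scatter) in this assay, because the step from compound 1 to compound 2 was a 1.2-fold higher number from compound 1 to compound 2 (0.10 log units; within the scatter) and lay within the scatter. Compound 4 is therefore estimated at 36 mL/min/kg in this assay, with a range from 22 mL/min/kg to 58 mL/min/kg.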

Compound 4, clearance: 61.8 mL/min/kg
For compound 4 the middle estimate is 1.7-fold (0.23 log units) below the measured one; the whole stated range lies below it.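

In this assay, methoxy in place of fluoro on the core of compound 3, on an aromatic carbon para to a large group, gives a 2.1-fold higher number from compound 3 to compound 4 (0.31 log units; beyond the scatter) and counts as a modest step. On the core of compound 1 the same change gave a 1.2-fold higher number from compound 1 to compound 2 (0.10 log units; within the scatter) and stayed inside the scatter, yet the gap between the two steps is itself no larger than two such steps would show by chance: the same change on two cores in this assay, a 1.2-fold higher number (0.10 log units; within the scatter) from compound 1 to compound 2 and a 2.1-fold higher number (0.31 log units; beyond the scatter) from compound 3 to compound 4, 1.7-fold (0.22 log units) apart, within the scatter of two such steps.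
Within the data shown here, these two pairs therefore give no ground for saying that the core alters the effect of this change, and both steps point to a higher number, but two pairs cannot show that the step carries over unchanged, and only the step on the core of compound 3 stands clear of the scatter.

The series shown compares only fluoro and methoxy at this place, so it remains open how a chloro group, a nitrile, a trifluoromethyl group or an amine there would read on either core. Whether a longer chain in place of the 4-fluorobenzyl or 4-methoxybenzyl group would follow the same course on both cores is also left open.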